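A Large Silicon-Bearing Group Enters on a Ring Nitrogen

The source may report more compounds than this note shows. Statements on the series, on what has been measured and on what is new or still open speak of the compounds shown alone.

Compound 1, `COCn1c(CC(O)(CO)CO)cc(=O)[nH]c1=O`: > 100000 nM in a functional assay on SW-620 cells (Homo sapiens) for antiproliferative activity, read by MTT assay, with a stated time of 72 h; on this read-out lower numbers stand for stronger inhibition and higher numbers for weaker inhibition
Compound 2, `O=c1cc(CC(O)COCc2ccccc2)[nH]c(=O)[nH]1`: > 100000 nM
Compound 3, `Cc1c(CC(O)COCc2ccccc2)[nH]c(=O)[nH]c1=O`: > 100000 nM

Of the compounds shown here, three have been measured so far, and none of them gave a number. In this assay compound 1 reaches only the limit of > 100000 nM. Compound 2 likewise stops at the limit of > 100000 nM. Compound 3 differs from compound 2 by a methyl in place of hydrogen on an aromatic carbon. Compound 3 also stays at the limit of > 100000 nM. So the step that the two limits leave unreadable from compound 2 to compound 3 cannot be read. Compound 3 therefore stands nowhere in particular: its value is a limit, as are the other two values shown, and the limit of > 100000 nM in this assay, at which 3 of the 3 values shown sit, is the whole of the evidence.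

Compound 4, `Cc1c(CC(O)COCc2ccccc2)n(COCC[Si](C)(C)C)c(=O)[nH]c1=O`, is the next candidate. The change from compound 3 is a group of 8 heavy atoms (6 carbon, 1 oxygen, 1 silicon; no ring) in place of a hydrogen atom, on an aromatic nitrogen. Among the compounds with values here, no measured step bears on a change of this kind, since the only step available is unreadable. With every measured compound sitting at the limit, the expectation for compound 4 is that it too most likely returns a limit, and any real number would have to appear below that ceiling. The estimated step of a number no higher from compound 3 to compound 4 (the limit leaves the size open) is therefore expected to be small or not readable. Compound 4 is estimated at 100000 nM, within a range from 20000 nM to 300000 nM.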

Compound 4, half-maximal inhibitory concentration: > 100000 nM
Compound 4 was reported as a limit; the forecaster's own chance of this, stated with the estimate: 70%; the middle value sits exactly at the limit.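

In this assay compound 4 gives > 100000 nM, which is a limit and not a number. Within the data shown here, compound 3 also stops at a limit, so no step between compound 3 and compound 4 can be read. The compounds shown leave open how strong any of them really is, and so what the silicon-bearing group does; the only evidence is this: the limit of > 100000 nM in this assay, at which 4 of the 4 values shown sit.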